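Swapping a Fluorinated Ring for a Pyrimidine on the Amide

A few compounds are considered here, and "the series" means these few. Any claim that something is new, unique, unknown or untested is made for them only; others in the source may bear on it.

Compound 1 `COc1ccc2nc(C)cc(OCC(=O)Nc3cccc(C)c3)c2c1` gives 39800 nM in a toxicity assay on HepG2 cells (Homo sapiens) for inhibition, read by CellTiter-Glo, with a stated time of 48 h; on this read-out higher numbers stand for weaker inhibition and lower numbers for stronger inhibition.
Compound 2 `COc1ccc2nc(C)cc(OCC(=O)Nc3cc(F)cc(F)c3)c2c1` gives > 100000 nM in this assay, which is a limit of the assay rather than a number.

Compounds 1 and 2 share one core and differ only in the ring on the amide-type nitrogen. Compound 2 stands at the weaker end of the two values shown, sitting at the limit of > 100000 nM in this assay, at which 1 of the 2 values shown sits. Among the compounds with values here, the one measured step, an at least 2.5-fold higher number from compound 1 to compound 2 (0.40 log units; beyond the scatter), also changed this ring and pushed the number up to that limit.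

Compound 3 `COc1ccc2nc(C)cc(OCC(=O)Nc3cc(C)nc(C)n3)c2c1` is not yet measured. It differs from compound 2 by 2,6-dimethylpyrimidin-4-yl in place of 3,5-difluorophenyl on an amide-type nitrogen. Within the data shown here, compound 2 offers only a limit, so no measured step shows whether a further ring change brings the number back down. The expected step is a number no higher from compound 2 to compound 3 (the limit leaves the size open), with compound 3 expected to stay near the limit. The estimate for compound 3 is 100000 nM, with a range from 40000 nM to 250000 nM.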

Compound 3, half-maximal inhibitory concentration: > 100000 nM
Compound 3 ended at the assay's limit; the forecaster's own chance of this, stated with the estimate: 60%; the middle value sits exactly at the limit.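

In this assay compound 3 gives > 100000 nM, which is a limit of the assay and not a number. Measured against the 3-methylphenyl ring of compound 1, the 2,6-dimethylpyrimidin-4-yl ring gives an at least 2.5-fold higher number from compound 1 to compound 3 (0.40 log units; beyond the scatter), so a second, quite different ring on the amide-type nitrogen also moves the number up and away from the value of compound 1. The step from compound 2 to compound 3 cannot be read, so these two rings cannot be ranked against each other, and the read-out now stops at one shared end: the limit of > 100000 nM in this assay, at which 2 of the 3 values shown sit.

Still open, as far as these compounds go, is how far above this limit compound 2 and compound 3 truly lie. Also open, from the compounds shown here alone, is whether a plain phenyl or a pyridine ring on the amide-type nitrogen would stay at the limit. Such a ring might instead bring the number back toward the value of compound 1, 39800 nM.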